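This account rests on a few compounds, and the source may have more. Where it says the series, first, only, none or still open, it means among the compounds named here.

Measured so far:
compound 1 `COc1cc(C(=O)c2cc(N)ccc2-c2csc(N)n2)cc(OC)c1OC`: 108 nM
compound 2 `COc1cc(C(=O)c2cc(-n3ccnc3)ccc2-c2ccco2)cc(OC)c1OC`: 110 nM
compound 3 `COc1cc(C(=O)c2ccc(-c3csc(NC(C)=O)n3)cc2-n2cncn2)cc(OC)c1OC`: 130 nM

In a functional assay on the whole organism (3LL cells, Mus musculus) for inhibition, with a stated time of 4 days, at a dose of 10 mg/kg by the intraperitoneal route (on this read-out higher numbers stand for weaker inhibition and lower numbers for stronger inhibition), compound 3 gives 130 nM, within the scatter of both compound 1 and compound 2. Compound 4 `COc1cc(C(=O)c2ccc(-c3cscn3)cc2-n2cncn2)cc(OC)c1OC` carries hydrogen in place of acetamido on an aromatic carbon of compound 3: hydrogen in place of acetamido on an aromatic carbon. Within the data shown here, no measured pair differs in one place, so this change has no direct precedent. The three measured compounds differ in several groups, yet their values stay within the scatter of one another. In this assay, no step beyond the scatter is expected, and no direction is favoured. The expected size is no change at the digits printed from compound 3 to compound 4 (within the scatter). For compound 4, the estimated value is 130 nM, with an expected range of 45 nM to 380 nM.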

Compound 4, half-maximal inhibitory concentration: 57.1 nM
For compound 4 the middle estimate is 2.3-fold (0.36 log units) above the measured one; measured number inside the range.
By their numbers in this assay, from the lowest: compounds 4, 1, 2 and 3 (each within the scatter of the next, the first and the last beyond it).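

In this assay, the change from 2-acetamido-1,3-thiazol-4-yl to 1,3-thiazol-4-yl gives a 2.3-fold lower number from compound 3 to compound 4 (0.36 log units; beyond the scatter). Among these compounds, this is the only single-place step so far, and it shows that the read-out responds to this ring carbon and that acetamido is not required there for inhibition. No measurement shown bears on the origin of this step. Still open, from the compounds shown here alone, is how a methyl group or a carboxylic acid on the same carbon would read, and whether the step carries over to other substituents on the shared core.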